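A Longer Dimethylamino Side Chain on the Shared Core

The compounds below may be only part of what the source reports. "The series", "measured", "known", "first", "only" and "open" are said of these compounds alone.

The three measured compounds share one core, shown for compound 1 as `CCCn1c(=O)n(CCC(=O)O)c(=O)c2[nH]cnc21`. In an assay on Cerebral cortex for binding affinity to adenosine receptor A1 (Cavia porcellus), read by radioligand binding (on this read-out higher numbers stand for weaker inhibition and lower numbers for stronger inhibition), compound 1 sits at > 200000 nM, which is a limit of the assay rather than a number. Compound 2 `CCCn1c(=O)n(CCC(N)=O)c(=O)c2[nH]cnc21` gives 31500 nM, and compound 3 `CCCn1c(=O)n(CCN(C)C)c(=O)c2[nH]cnc21` gives 4300 nM, the lowest number shown, with the step of a 7.3-fold lower number from compound 2 to compound 3 (0.86 log units; beyond the scatter) lying beyond the scatter. Compound 4 `CCCn1c(=O)n(CCCN(C)C)c(=O)c2[nH]cnc21` differs from compound 3 by (dimethylamino)methyl in place of dimethylamino on a saturated chain carbon, two bonds along the chain from an aromatic nitrogen. Among the compounds with values here, no measured step alters the chain length: an at least 6.3-fold lower number from compound 1 to compound 2 (0.80 log units; beyond the scatter) and an at least 46-fold lower number from compound 1 to compound 3 (1.66 log units; beyond the scatter) exchange only the group at the chain end. With nothing bearing directly on this change, the expectation is a step within the scatter. Compound 4 is therefore estimated at 3000 nM, within 800 nM to 10000 nM, an expected 1.4-fold lower number from compound 3 to compound 4 (0.16 log units; within the scatter).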

Compound 4, inhibition constant: 43200 nM
Estimate against measurement, compound 4: 14-fold (1.16 log units) below, outside the stated range (above it).
By their numbers in this assay, from the lowest: compound 3; then compounds 2 and 4 (each within the scatter of the next). At a limit, above all of these: compound 1.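

Lengthening 2-(dimethylamino)ethyl to 3-(dimethylamino)propyl gives a 10-fold higher number from compound 3 to compound 4 (1.00 log units; beyond the scatter), so this position responds to chain length as well as to the group at the chain end, which no earlier step could show. The longer chain also gives up the lead the dimethylamino end held over carbamoyl, with a 1.4-fold higher number from compound 2 to compound 4 (0.14 log units; within the scatter). Against carboxy, the change gives an at least 4.6-fold lower number from compound 1 to compound 4 (0.66 log units; beyond the scatter), a step resting on a limit of the assay: the limit of > 200000 nM in this assay, at which 1 of the 4 values shown sits.

Still open, going by these compounds, is whether a yet longer chain ending in dimethylamino would continue this trend. On these data alone, a primary amine or a pyrrolidine at the end of the shorter chain also remains untested here.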